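The source may hold more compounds than are shown below. What is called first, only, known or untested is meant among the compounds shown, and "the series" means these compounds.

Working notes on the series.

Compound 3 `COc1ccc(C2CC(c3cc(Cl)c(C)cc3O)=NN2c2ccc(S(N)(=O)=O)cc2)cc1OC` is the reference point for the next step. In a functional assay on CAKI-1 cells (Homo sapiens) for antiproliferative activity, with a stated time of 48 h (a higher number here means that more compound is tolerated, a lower number that less compound is tolerated), compound 3 reaches only a limit of the assay, > 100000 nM. The neighbouring compound 2 `Cc1cc(O)c(C2=NN(c3ccc(S(N)(=O)=O)cc3)C(/C=C/c3ccccc3)C2)cc1Cl` likewise sits at a limit in this assay, > 100000 nM. For the measured compounds named here, compound 1 `Cc1cc(O)c(C2=NN(c3ccc(S(N)(=O)=O)cc3)C(c3ccccc3O)C2)cc1Cl` is the one member with a number, giving 16600 nM in this assay. Both measured steps away from compound 1 run upward: an at least 6.0-fold higher number from compound 1 to compound 2 (0.77 log units; beyond the scatter) and an at least 6.0-fold higher number from compound 1 to compound 3 (0.77 log units; beyond the scatter). Between compound 2 and compound 3 the step is unreadable, a step that the two limits leave unreadable from compound 2 to compound 3, because of the limit of > 100000 nM in this assay, at which 2 of the 3 values shown sit.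

Compound 4 `COc1ccc(C2CC(c3cc(Cl)c(C)cc3O)=NN2c2ccc(S(N)(=O)=O)cc2)c(OC)c1OC` differs from compound 3 by methoxy in place of hydrogen on an aromatic carbon. Going by the values given here, no measured step exchanges a hydrogen for a methoxy group, so none bears on this change directly; the steps that are known, an at least 6.0-fold higher number from compound 1 to compound 2 (0.77 log units; beyond the scatter) and an at least 6.0-fold higher number from compound 1 to compound 3 (0.77 log units; beyond the scatter), only say that the dimethoxyphenyl member already tolerates more compound than compound 1 can resolve. The starting point for compound 4 is therefore a limit, not a number, and the expectation is that the step of a number no higher from compound 3 to compound 4 (the limit leaves the size open) stays within the scatter, most probably with compound 4 again at the limit. For compound 4 the estimate in this assay is 100000 nM, with a range from 30000 nM to 300000 nM.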

Compound 4, concentration lethal to 50% of the cells: > 100000 nM
Compound 4: only a limit was reported; the forecaster's own chance of this, stated with the estimate: 70%; the middle value sits exactly at the limit.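

With 2,3,4-trimethoxyphenyl in place of 2-hydroxyphenyl on the saturated ring carbon, the series shows an at least 6.0-fold higher number from compound 1 to compound 4 (0.77 log units; beyond the scatter), the same lower bound that the two earlier replacements gave. For the compounds shown here, a further methoxy on the aromatic carbon, ortho to a large group and ortho to a methoxy group, therefore does not bring the value in this assay down from the limit, and compound 1 remains the only member with a number and the exception among the four compounds. The steps from compound 3 to compound 4 and from compound 2 to compound 4 cannot be read, because both ends of each step sit at the same limit: the limit of > 100000 nM in this assay, at which 3 of the 4 values shown sit.

From the compounds shown here alone, how far compound 2, compound 3 and compound 4 lie beyond that limit remains open, so the size of any effect of the added methoxy is unknown. Also open, going by these compounds, is whether an amine or a carboxylic acid in place of the hydroxyl of the 2-hydroxyphenyl group would keep a value below the limit in this assay.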